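A few compounds are considered here, and "the series" means these few. Any claim that something is new, unique, unknown or untested is made for them only; others in the source may bear on it.

Compound 1, with the structure `CCOC(=O)C1=C(S[C@@H]2CN[C@H](C(=O)Nc3cccc(C(=O)OCC)c3)C2)[C@H](C)[C@@H]2[C@@H]([C@@H](C)OC(=O)CC)C(=O)N12`, is the only one of this set with a number to show: in an ADME assay on the whole organism (plasma, strain Beagle) for pharmacokinetics, with Canis familiaris (Canis lupus familiaris) as the target, read by LC-MS, with a stated time of 8 h, at a dose of 10 mg/kg by the intraduodenal route (a higher number here means more compound in the circulation at the dose given, a lower number less compound in the circulation), compound 1 gives 940 ng.h/mL. Two related compounds were also examined: compound 2, with the structure `CC(=O)O[C@H](C)[C@H]1C(=O)N2C3=C(S[C@@H]4CN[C@@H](C4)C(=O)Nc4cccc(c4)C(=O)OCOCOC3=O)[C@H](C)[C@H]12`, and compound 3, with the structure `CCCOC(=O)C1=C(S[C@@H]2CN[C@H](C(=O)Nc3cccc(C(=O)OCCC)c3)C2)[C@H](C)[C@@H]2[C@@H]([C@@H](C)O)C(=O)N12`. In this assay compound 2 gives "not determined" (no result reported). In this assay compound 3 gives "not determined" (no result reported). Since no result was reported for either of them, compound 1 stands alone and cannot be placed higher or lower than any other compound.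

Compound 4, with the structure `CCOC(=O)C1=C(S[C@@H]2CN[C@H](C(=O)Nc3cccc(C(=O)OCC)c3)C2)[C@H](C)[C@@H]2[C@@H]([C@@H](C)OC(C)=O)C(=O)N12`, has not yet been measured. It differs from compound 1 in one place: hydrogen in place of methyl on a saturated chain carbon bound to a carbonyl carbon. The change is the cut from propanoyloxy to acetoxy, a small trim on the ester that sits on the side chain of the shared core.

Within the data shown here, with no measured step of this kind available, the expectation for the step from compound 1 to compound 4 is one that stays within the usual scatter, that is a 1.0-fold lower number from compound 1 to compound 4 (0.02 log units; within the scatter), without a clear direction. For compound 4 the estimated result in this assay is 900 ng.h/mL, with a range from 400 ng.h/mL to 2000 ng.h/mL.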

Compound 4, area under the concentration-time curve: 1260 ng.h/mL
Beside the measured number, compound 4's estimate is 1.4-fold (0.15 log units) below it; the measured number falls inside the stated range.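

In this assay, among these compounds, the cut from propanoyloxy to acetoxy gives a 1.3-fold higher number from compound 1 to compound 4 (0.13 log units; within the scatter) and is the only measured step at this place, so the earlier compounds could not show what it shows. Hydrogen in place of methyl on a saturated chain carbon bound to a carbonyl carbon makes no change here that stands clear of ordinary repeat variation, so this small trim on the side-chain ester is tolerated in this pair. Nothing measured on hand explains why the number holds across this step.

This single pair cannot say whether the same holds for larger changes at this place. A longer chain such as butanoyloxy, or an amine carried on the same chain, remains an open question.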